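The source may hold more compounds than are shown below. What is called first, only, known or untested is meant among the compounds shown, and "the series" means these compounds.

In a functional assay on A549 cells (Homo sapiens) for inhibition, read by MTT assay, with a stated time of 72 h (a higher number here means a weaker inhibitor, a lower number a stronger inhibitor), compound 1 `COc1cc(O)c(CC=C(C)C)c(O)c1C(=O)/C=C/c1ccc(Cl)cc1` gives 11800 nM and compound 2 `COc1cc(OC)c(C(=O)/C=C/c2ccc(O)c(O)c2)c(OC)c1` gives 8200 nM, two values within the usual scatter of each other. Compound 3 `COc1cc(OC)c(C(=O)/C=C/c2ccc(Cl)cc2)c(OC)c1` has not yet been measured. It differs from compound 2 as follows: 4-chlorophenyl in place of 3,4-dihydroxyphenyl on a double-bonded chain carbon bound to a double-bonded chain carbon. This puts 4-chlorophenyl in place of 3,4-dihydroxyphenyl on a double-bonded chain carbon bound to a double-bonded chain carbon. Among the measured compounds shown here, no measured pair shows this change alone, but compound 1 also carries 4-chlorophenyl and gives 11800 nM, so only a small rise is expected. The estimated step is a 1.2-fold higher number from compound 2 to compound 3 (0.09 log units; within the scatter), which stays within the scatter. For compound 3, the expected value is 10000 nM, with an estimated range of 4000 nM to 25000 nM.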

Compound 3, half-maximal inhibitory concentration: 13300 nM
Estimate against measurement, compound 3: 1.3-fold (0.12 log units) below; low and high end bracket the measured number.
By their numbers in this assay, from the lowest: compounds 2, 1 and 3 (each within the scatter of the next).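

Among the compounds shown here, putting 4-chlorophenyl in place of 3,4-dihydroxyphenyl on a double-bonded chain carbon bound to a double-bonded chain carbon gives, in this assay, a 1.6-fold higher number from compound 2 to compound 3 (0.21 log units; within the scatter), the first direct reading of this change. Losing the 2 hydrogen-bond donors and 2 hydrogen-bond acceptors counted on the leaving group therefore does not separate the two compounds in this assay. Nothing available explains this result.

On these data alone, whether an amine, a carboxylic acid or a longer chain at this position would move the number beyond the scatter remains open.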